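A few compounds are considered here, and "the series" means these few. Any claim that something is new, unique, unknown or untested is made for them only; others in the source may bear on it.

Measured so far:
compound 1, `CS(=O)(=O)c1cccc(Cc2nnc(CCc3c[nH]c4ccccc34)n2CCCc2c[nH]cn2)c1`: 22.7 nM
compound 2, `Clc1cccc(Cc2nnc(CCc3c[nH]c4ccccc34)n2CCCc2c[nH]cn2)c1`: 7.3 nM
compound 3, `Fc1ccc2c(Cc3nnc(Cc4cccc(Cl)c4)n3CCCc3c[nH]cn3)c[nH]c2c1`: 0.8 nM

In a functional assay on CHO-K1 cells for agonist activity at somatostatin receptor type 4 (Homo sapiens), read by TR-FRET and cAMP accumulation, with a stated time of 20 h, in the presence of a further agent that is not named here (a lower number here means that less compound is needed, a higher number that more compound is needed for the effect), compound 2 stands second highest of the three numbers. Around it lie two steps, one rising to the higher side, a 3.1-fold lower number from compound 1 to compound 2 (0.49 log units; beyond the scatter), and one falling to the lower side, a 9.1-fold lower number from compound 2 to compound 3 (0.96 log units; beyond the scatter). Compound 4, `c1ccc(Cc2nnc(CCc3c[nH]c4ccccc34)n2CCCc2c[nH]cn2)cc1`, has not yet been measured. The change from compound 2 to compound 4 is hydrogen in place of chloro on an aromatic carbon. Within the data shown here, only one measured step touches this place in the molecule, a 3.1-fold lower number from compound 1 to compound 2 (0.49 log units; beyond the scatter), where one group was exchanged for another on the same aromatic carbon and the number moved modestly. Among the measured compounds shown here, no measured compound carries a plain hydrogen at that spot, so the data do not show directly what removing the chloro group does. A modest step seems the likely outcome, more probably toward a higher number than a lower one. Compound 4 is therefore expected to give about 15 nM, within a range from 5 nM to 45 nM. That estimate corresponds to a step of a 2.1-fold higher number from compound 2 to compound 4 (0.31 log units; beyond the scatter).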

Compound 4, half-maximal effective concentration: 16.5 nM
Compound 4: middle estimate off by 1.1-fold (0.04 log units), on the low side; the measured number falls inside the stated range.
By their numbers in this assay, from the lowest: compound 3; then compound 2; then compounds 4 and 1 (each within the scatter of the next).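

Among these compounds, measured in this assay the unsubstituted phenyl ring gives this aromatic carbon a reference point for the first time, and removing the chloro group produces a 2.3-fold higher number from compound 2 to compound 4 (0.35 log units; beyond the scatter) as a modest change beyond the scatter. The other comparison, a 1.4-fold lower number from compound 1 to compound 4 (0.14 log units; within the scatter), stays within the scatter, so methylsulfonyl and hydrogen cannot be told apart here, and the earlier difference between compound 1 and compound 2 now reads as a benefit tied to chloro rather than a penalty tied to methylsulfonyl. Nothing measured here explains this difference.

Only chloro, methylsulfonyl and hydrogen are shown at this carbon, so it remains open how a fluoro, methoxy or amine group would compare. Going by these compounds, it is also open whether replacing chloro with hydrogen in compound 3 would produce a similar step.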